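The source may hold more compounds than are shown below. What is called first, only, known or untested is meant among the compounds shown, and "the series" means these compounds.

Compound 1 `COc1cc(C(=O)N2CCc3ccccc32)cc(C#N)c1O` gives > 100000 nM in an assay on tissue (RPTEC cells) for inhibition of solute carrier family 22 member 12 (Homo sapiens), read by scintillation counting, with stated times of 15 min and 2 h (on this read-out higher numbers stand for weaker inhibition and lower numbers for stronger inhibition), which is a limit of the assay and not a number. Compound 2 `N#Cc1cc(C(=O)N2CCc3ccccc32)cc(I)c1O` gives 5300 nM in this assay. Compound 3 `N#Cc1cc(C(=O)N2CCc3ccccc32)cc(C#N)c1O` gives 83900 nM in this assay.

Among the two numbers shown, compound 3 holds the highest, the step being a 16-fold higher number from compound 2 to compound 3 (1.20 log units; beyond the scatter). The value of compound 1 sits at the limit of > 100000 nM in this assay, at which 1 of the 3 values shown sits, so only its floor is known, and an at least 1.1-fold lower number from compound 1 to compound 3 (0.07 log units; that floor lies within the scatter) tells no more than that.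

Compound 4 `N#Cc1cc(C(=O)N2CCc3ccccc32)cc(C2CC2)c1O` differs from compound 3 in one place: cyclopropyl in place of cyano on an aromatic carbon. For the measured compounds named here, three measured steps bear on this position. Replacing methoxy by iodo gave an at least 18-fold lower number from compound 1 to compound 2 (1.27 log units; beyond the scatter), replacing iodo by cyano gave a 16-fold higher number from compound 2 to compound 3 (1.20 log units; beyond the scatter), and the change from methoxy to cyano gave an at least 1.1-fold lower number from compound 1 to compound 3 (0.07 log units; that floor lies within the scatter). Cyano is thus the group that gives the highest number at this position, and iodo the lowest. Cyclopropyl is neither; the step to compound 4 is therefore expected to lower the number in this assay, by roughly a 7.0-fold lower number from compound 3 to compound 4 (0.84 log units; beyond the scatter), though by less than iodo achieved. Compound 4 is expected to give about 12000 nM in this assay, within a range from 3000 nM to 50000 nM.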

Compound 4, half-maximal inhibitory concentration: 8800 nM
The estimate for compound 4 lay 1.4-fold (0.13 log units) above the measured number; the measured number falls inside the stated range.
By their numbers in this assay, from the lowest: compounds 2 and 4 (each within the scatter of the next); then compound 3. At a limit, above all of these: compound 1.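

In this assay, cyclopropyl in place of cyano gives a 9.5-fold lower number from compound 3 to compound 4 (0.98 log units; beyond the scatter), and cyclopropyl in place of iodo gives a 1.7-fold higher number from compound 2 to compound 4 (0.22 log units; within the scatter), so a low number at this position, ortho to a hydroxy group, does not depend on iodo: a group of carbon only, with no hydrogen-bond acceptor, matches it within the scatter. Against methoxy, the change gives an at least 11-fold lower number from compound 1 to compound 4 (1.05 log units; beyond the scatter). Compound 1 stands at a limit of the assay and not at a number, so that step is only a floor: the limit of > 100000 nM in this assay, at which 1 of the 4 values shown sits.

The compounds shown leave open whether the number at this position would hold with an amine, a carboxylic acid or a longer alkyl chain. They also leave open whether cyclopropyl gives the same step once the remaining cyano group or the hydroxy group is replaced.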